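A few compounds are considered here, and "the series" means these few. Any claim that something is new, unique, unknown or untested is made for them only; others in the source may bear on it.

Of the compounds shown here, three measured so far share one core and differ only in the group hanging from it. In a functional assay on MCF7 cells (Homo sapiens) for inhibition, read by MTT assay, with a stated time of 72 h (a lower number here means a stronger inhibitor, a higher number a weaker inhibitor), compound 1 `Cc1cc(Nc2cc(-c3ccccc3)[nH]n2)n2nc(SCc3ccc([N+](=O)[O-])cc3)nc2n1` gives 5060 nM, the higher of the two numbers read, with compound 3 `Cc1cc(Nc2cc(-c3ccccc3)[nH]n2)n2nc(SCc3csc4ccccc34)nc2n1` nearest at 3470 nM; the gap a 1.5-fold lower number from compound 1 to compound 3 (0.16 log units; within the scatter) is one a repeat measurement could erase. Compound 2 `Cc1cc(Nc2cc(-c3ccccc3)[nH]n2)n2ncnc2n1` gives no number at all but > 50000 nM, which is the limit of > 50000 nM in this assay, at which 1 of the 3 values shown sits. Removing the whole sulfur-linked group is the step of an at least 9.8-fold higher number from compound 1 to compound 2 (0.99 log units; beyond the scatter), and putting a different sulfur-linked group back is the step of an at least 14-fold lower number from compound 2 to compound 3 (1.15 log units; beyond the scatter). So the presence of a benzyl-type group on the sulfur matters greatly, while the choice of aromatic ring at its end has made no visible difference.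

Compound 4 `Cc1cc(Nc2cc(-c3ccccc3)[nH]n2)n2nc(SCc3ccccc3Br)nc2n1` is not yet measured. It differs from compound 1 as follows: 2-bromophenyl in place of 4-nitrophenyl on a saturated chain carbon bound to a sulfur. The step that bears most directly on it is the swap of aromatic ring in a 1.5-fold lower number from compound 1 to compound 3 (0.16 log units; within the scatter), which stayed within the scatter. The change from compound 1 to compound 4 is therefore expected to be a 1.2-fold lower number from compound 1 to compound 4 (0.08 log units; within the scatter). Compound 4 is estimated to give 4200 nM in this assay, most likely between 1500 nM and 12000 nM.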

Compound 4, half-maximal inhibitory concentration: 3020 nM
Compound 4: the middle estimate sits 1.4-fold (0.14 log units) above what was measured; the range from low to high includes it.
By their numbers in this assay, from the lowest: compounds 4, 3 and 1 (each within the scatter of the next). At a limit, above all of these: compound 2.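

In this assay, 2-bromophenyl in place of 4-nitrophenyl gives a 1.7-fold lower number from compound 1 to compound 4 (0.22 log units; within the scatter), and 2-bromophenyl in place of 1-benzothiophen-3-yl gives a 1.1-fold lower number from compound 3 to compound 4 (0.06 log units; within the scatter), so a third aromatic end on the saturated chain carbon bound to a sulfur again leaves the value within the scatter, even though this one carries bromine and has no hydrogen-bond acceptors. The sulfur-linked group as a whole still counts, since (2-bromobenzyl)sulfanyl in place of hydrogen on an aromatic carbon gives an at least 16-fold lower number from compound 2 to compound 4 (1.21 log units; beyond the scatter). That step has only one firm end, as compound 2 gives a limit and not a number: the limit of > 50000 nM in this assay, at which 1 of the 4 values shown sits.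

Every end shown so far is an aromatic ring, so it remains open whether a cyclohexyl ring, a plain butyl chain or a benzyl group carrying an amine or a carboxylic acid would hold this level. Compound 1, compound 3 and compound 4 also cannot be told apart here, which leaves open whether any change at this end can move the value beyond the scatter in either direction.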